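Methyl on the Thiazole of a Toll-like Receptor 8 Agonist

This account rests on a few compounds, and the source may have more. Where it says the series, first, only, none or still open, it means among the compounds named here.

Compound 1 `CCCCNc1nc(N)nc2c1CN(C(=O)c1ccccc1)CC2`: 1.4 uM
Compound 2 `CCCCNc1nc(N)nc2c1CN(C(=O)c1cscn1)CC2`: 0.5 uM

In an assay on HEK293 cells for agonist activity at Toll-like receptor 8 (Homo sapiens), read by a luciferase reporter, with a stated time of 6 h (on this read-out lower numbers stand for an effect already at smaller amounts and higher numbers for an effect only at larger amounts of compound), compound 2 gives the lowest of the two numbers; its nearest neighbour is compound 1, and the step of a 2.8-fold lower number from compound 1 to compound 2 (0.45 log units; beyond the scatter) came with 1,3-thiazol-4-yl in place of phenyl on a carbonyl carbon. Compound 3 `CCCCNc1nc(N)nc2c1CN(C(=O)c1csc(C)n1)CC2` differs from compound 2 by methyl in place of hydrogen on an aromatic carbon. Among the compounds with values here, no measured step touches this change, so no step beyond the scatter is expected in this assay. Compound 3 is therefore estimated at 0.5 uM with a range of 0.2 uM to 1.2 uM, which means an expected step of no change at the digits printed from compound 2 to compound 3 (within the scatter).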

Compound 3, minimum effective concentration: 1.8 uM
Compound 3: middle estimate off by 3.6-fold (0.56 log units), on the low side; the whole stated range lies below it.
By their numbers in this assay, from the lowest: compound 2; then compounds 1 and 3 (each within the scatter of the next).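

Methyl in place of hydrogen gives a 3.6-fold higher number from compound 2 to compound 3 (0.56 log units; beyond the scatter) in this assay on the thiazole carbon next to the ring nitrogen and next to the ring sulfur, so this position does not tolerate every small change. Against phenyl on the carbonyl carbon, 2-methyl-1,3-thiazol-4-yl gives a 1.3-fold higher number from compound 1 to compound 3 (0.11 log units; within the scatter) and thus lacks the separation from compound 1 that compound 2 showed. Nothing available explains this step. As far as these compounds go, whether an amine or an ethyl chain at this same position would behave like methyl stays open.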